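Alanine-type side chain on the drimane quinone series

This account rests on a few compounds, and the source may have more. Where it says the series, first, only, none or still open, it means among the compounds named here.

Compound 1 `CC1=CCC[C@H]2[C@](C)(CC3=CC(=O)C=C(NCCC(=O)O)C3=O)[C@@H](C)CC[C@]12C` gives the lowest number of the three measured in a functional assay on MDA-MB-453 cells (Homo sapiens) for cytotoxicity, read by MTT assay, with a stated time of 72 h (a higher number here means a weaker inhibitor, a lower number a stronger inhibitor), with 3310 nM. The two analogues carrying a tert-butyl group on the core in its place sit far higher: compound 2 `CC(C)(C)C1=CC(=O)C=C(NCC(=O)O)C1=O` gives 171000 nM and compound 3 `CC(C)[C@@H](NC1=CC(=O)C=C(C(C)(C)C)C1=O)C(=O)O` gives 133000 nM, so compound 1 stands well beyond the scatter from both.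

Compound 4 `CC1=CCC[C@H]2[C@](C)(CC3=CC(=O)C=C(N[C@@H](C)C(=O)O)C3=O)[C@@H](C)CC[C@]12C` is not yet measured. It differs from compound 1 by 1-carboxyethyl in place of 2-carboxyethyl on an amine nitrogen. For the measured compounds named here, the only measured step that touches a related change is the branching on the chain carbon bound to the amine nitrogen, a 1.3-fold lower number from compound 2 to compound 3 (0.11 log units; within the scatter), which stayed within the scatter. Going by the values given here, no measured pair compares the two chain attachments directly, so the shift of the carboxyl along the chain is untested. On that basis the step in this assay is expected to be small, and a 1.1-fold higher number from compound 1 to compound 4 (0.02 log units; within the scatter) is estimated with no clear direction. Compound 4 is therefore expected to give about 3500 nM, within a range of 1200 nM to 10000 nM.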

Compound 4, half-maximal inhibitory concentration: 14700 nM
Compound 4: the middle estimate sits 4.2-fold (0.62 log units) below what was measured; the whole stated range lies below it.
By their numbers in this assay, from the lowest: compound 1; then compound 4; then compounds 3 and 2 (each within the scatter of the next).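

In this assay, the attachment of the carboxyl-bearing chain on the amine nitrogen is not a silent change on the core of compound 1: a 4.4-fold higher number from compound 1 to compound 4 (0.65 log units; beyond the scatter). For the compounds shown here, the only earlier step on this chain, a 1.3-fold lower number from compound 2 to compound 3 (0.11 log units; within the scatter), lay within the scatter on the tert-butyl core, so this is the first change at this position to exceed it. In compound 4 the 1-carboxyethyl group also brings a defined stereocentre, so the shift of attachment and the stereocentre enter together, and no measurement available here bears on why the number rises.

Still open, going by these compounds, is whether the mirror-image 1-carboxyethyl group would give a number closer to that of compound 1 or compound 4. On these data alone, the effect on this core of a longer chain such as 3-carboxypropyl, or of a primary amide in place of the carboxylic acid, is also open.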